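From 4-methylpiperazin-1-yl to phenoxy on the shared core

This account rests on a few compounds, and the source may have more. Where it says the series, first, only, none or still open, it means among the compounds named here.

Compound 1 (`CCOC(=O)c1ccc(-c2ccc(N(CC)CC)nn2)cc1`) gives 9000 nM
Compound 2 (`CN1CCN(c2ccc(-c3cccc(C(F)(F)F)c3)nn2)CC1`) gives 30000 nM

In a functional assay on Huh-7 cells (Homo sapiens) for antiproliferative activity, with a stated time of 48 h (a lower number here means a stronger inhibitor, a higher number a weaker inhibitor), only these two compounds have been measured, and compound 2 at 30000 nM holds the higher number of the pair, a gap beyond the usual scatter. It is therefore the weaker inhibitor of the two in this short series.

Compound 3 (`FC(F)(F)c1cccc(-c2ccc(Oc3ccccc3)nn2)c1`) carries phenoxy in place of 4-methylpiperazin-1-yl on an aromatic carbon and otherwise matches compound 2. Going by the values given here, no measured pair shows this change, so any forecast rests on thin evidence. Among the compounds with values here, the only other reference is compound 1 at 9000 nM and that number lies lower, so a small move toward a lower number is expected, perhaps a little beyond the scatter. The expected change is a 2.5-fold lower number from compound 2 to compound 3 (0.40 log units; beyond the scatter) and it remains only an estimate. Compound 3 is estimated at 12000 nM with a likely range from 3000 nM to 45000 nM in this assay.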

Compound 3, half-maximal inhibitory concentration: > 25000 nM
Compound 3: a limit, no number; the forecaster's own chance of this, stated with the estimate: 20%; middle value at least 2.0-fold (0.31 log units) from the limit.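

In this assay, going by these compounds alone, compound 3 gives > 25000 nM, which is a limit of the assay and not a number, so no step from compound 2 to compound 3 can be read. The compounds shown leave open whether phenoxy in place of 4-methylpiperazin-1-yl changes the number in this assay at all, and in which direction.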